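Swapping cyclohexyl for benzyl on a shared core

The source may report more compounds than this note shows. Statements on the series, on what has been measured and on what is new or still open speak of the compounds shown alone.

Of the compounds shown here, three have been tested in a functional assay on UACC-62 cells (Homo sapiens) for inhibition, read by sulforhodamine B assay, with a stated time of 48 h, tested at 10 uM; a higher number here means more inhibition at the concentration tested (going by the name of the read-out), a lower number less inhibition. Compound 1 `Fc1ccc(-c2cn3ccnc3c(-c3ccc4ncn(C5CCCCC5)c4c3)n2)cc1` gives 31%, compound 2 `c1csc(-c2cn3ccnc3c(-c3ccc4ncn(C5CCCCC5)c4c3)n2)c1` gives 24.8%, and compound 3 `c1cn2cc(-c3ccc4c(c3)ncn4C3CCCCC3)nc(-c3ccc4ncn(C5CCCCC5)c4c3)c2n1` gives 29.3%. Compound 3 therefore stands second highest of the three numbers; its nearest neighbour is compound 1, whose number is higher by an amount within the scatter, and its furthest is compound 2, whose number is lower, again within the scatter. For the measured compounds named here, the one measured step, a number 6.2 percentage points lower from compound 1 to compound 2 (within the scatter), exchanges one group on an aromatic carbon and stays within the scatter.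

Compound 4 `c1ccc(Cn2cnc3ccc(-c4nc(-c5ccc6c(c5)ncn6C5CCCCC5)cn5ccnc45)cc32)cc1` is not yet measured. It differs from compound 3 in one place: benzyl in place of cyclohexyl on an aromatic nitrogen. The group that leaves and the group that enters are of similar size and carry no hydrogen-bond donors or acceptors. Going by the values given here, no measured step touches this position on the aromatic nitrogen, so there is nothing to suggest a shift beyond the scatter, and the step in this assay from compound 3 to compound 4 is expected to be small, a number 0.3 percentage points lower from compound 3 to compound 4 (within the scatter). Compound 4 is estimated to give about 29% in this assay, within a range from 14% to 45%.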

Compound 4, a percentage reported as inhibition, at one concentration (the size of the read-out at that concentration, not a potency): -31.2%
Beside the measured number, compound 4's estimate is 60.2 percentage points above it, and the stated range ends above it.
By their numbers in this assay, from the lowest: compound 4; then compounds 2, 3 and 1 (each within the scatter of the next).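

Every earlier compound carries cyclohexyl on this aromatic nitrogen, so none of them could show how much this position matters. In this assay, benzyl in place of cyclohexyl brings a large change (a number 60.5 percentage points lower from compound 3 to compound 4 (beyond the scatter)), although the counts of hydrogen-bond donors and acceptors stay the same. The two groups are of similar size, yet in this assay compound 4 gives -31.2%. Nothing measured here explains the drop.

As far as these compounds go, it remains open whether the change depends on the aromatic ring of benzyl or on how that ring is attached to the nitrogen. Phenyl, a longer chain such as 2-phenylethyl, or a small methyl on this nitrogen would help separate these possibilities.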